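Cyanophenyl Ether in Place of the Pyridyl Ester

The source may report more compounds than this note shows. Statements on the series, on what has been measured and on what is new or still open speak of the compounds shown alone.

Going by the values given here, compound 1 `COC(=O)c1cccc(OC(c2ccc(C(F)(F)F)cc2)C2CCN(C(C)CCNC(=O)c3c(Cl)cncc3Cl)CC2)n1` is one of two compounds measured in an ADME assay on PBMC cells (Homo sapiens) for cytotoxicity; a lower number here means that less compound is tolerated, a higher number that more compound is tolerated; there compound 1 gives 14600 nM, the lowest of the two numbers. Compound 2 `CC(CCNC(=O)c1c(Cl)cncc1Cl)N1CCC(C(Oc2ccncc2)c2ccc(Br)cc2)CC1` gives 31200 nM in this assay, a higher number beyond the usual scatter. Compound 3 `CC(CCNC(=O)c1c(Cl)cncc1Cl)N1CCC(C(Oc2ccccc2C#N)c2ccc(C(F)(F)F)cc2)CC1` has not yet been measured. It differs from compound 1 in one place: 2-cyanophenyl in place of 6-(methoxycarbonyl)pyridin-2-yl on an oxygen on a saturated carbon. Among the compounds with values here, no measured pair shows this change; the step from compound 1 is expected to be small, no more than modestly upward. Compound 3 is expected to give 20000 nM, within a range from 8000 nM to 50000 nM. The expected step of a 1.4-fold higher number from compound 1 to compound 3 (0.14 log units; within the scatter) is thus a small one.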

Compound 3, half-maximal cytotoxic concentration: 17000 nM
Compound 3: middle estimate off by 1.2-fold (0.07 log units), on the high side; the range from low to high includes it.
By their numbers in this assay, from the lowest: compounds 1, 3 and 2 (each within the scatter of the next, the first and the last beyond it).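

In this assay, 2-cyanophenyl in place of 6-(methoxycarbonyl)pyridin-2-yl on this oxygen gives a 1.2-fold higher number from compound 1 to compound 3 (0.07 log units; within the scatter). This first comparison of compounds differing in one place shows that exchanging the pyridine ring and its ester for a carbon-only ring bearing a nitrile leaves the number within the scatter. For this pair, the read-out does not separate the two groups.

From the compounds shown here alone, whether an aminophenyl or carboxyphenyl group on this oxygen would read the same remains open. Nothing measured here explains the result.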